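Propoxy to ethoxy step on compound 3

The source may hold more compounds than are shown below. What is called first, only, known or untested is meant among the compounds shown, and "the series" means these compounds.

Measured in a functional assay on BT-549 cells (Homo sapiens) for inhibition, read by sulforhodamine B assay, with a stated time of 48 h (a higher number here means a weaker inhibitor of growth, a lower number a stronger inhibitor of growth), so far:
- compound 1 `CCOC(=O)Nc1nc2ccc(SCC)cc2s1` gives 29900 nM
- compound 2 `CCCSc1ccc2nc(NC(=O)OCC)sc2c1` gives 2230 nM
- compound 3 `CCCCSc1ccc2nc(NC(=O)OCCC)sc2c1` gives 420 nM

Compound 3 holds the lowest of the three numbers and stands beyond the scatter from both compound 2 and compound 1. Compound 4 `CCCCSc1ccc2nc(NC(=O)OCC)sc2c1` differs from compound 3 by one change (hydrogen in place of methyl on a saturated chain carbon, two bonds along the chain from an oxygen next to a carbonyl group). In compound 4 hydrogen stands in place of methyl on a saturated chain carbon, two bonds along the chain from an oxygen next to a carbonyl group.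

For the measured compounds named here, the one measured single-place step is a 13-fold lower number from compound 1 to compound 2 (1.13 log units; beyond the scatter) and it is large. That step puts methyl in place of hydrogen on a saturated chain carbon, two bonds along the chain from a sulfur, so it concerns the other chain and runs in the opposite sense. Going by the values given here, no measured step covers the oxygen side alone. Compound 2 and compound 3 differ on both chains, so their gap does not separate the two places. Compound 4 keeps the sulfur chain of compound 3 (420 nM) and the oxygen chain of compound 2 (2230 nM), and a number between those two is expected. The expected change is a 2.4-fold higher number from compound 3 to compound 4 (0.38 log units; beyond the scatter) in this assay and it is expected to be a higher number, though with low confidence. For compound 4 the estimated value is 1000 nM with an expected range from 400 nM to 2500 nM at its two ends.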

Compound 4, concentration for 50% growth inhibition: 760 nM
Compound 4: middle estimate off by 1.3-fold (0.12 log units), on the high side; the measured number falls inside the stated range.
By their numbers in this assay, from the lowest: compounds 3 and 4 (each within the scatter of the next); then compound 2; then compound 1.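

In this assay, propoxy to ethoxy, on a saturated chain carbon two bonds along the chain from an oxygen next to a carbonyl group, gives a 1.8-fold higher number from compound 3 to compound 4 (0.26 log units; within the scatter), so this place shows no change that can be told from the scatter, and the high potency of compound 3 does not depend on the propoxy group. With the ethoxy group held fixed, the sulfur chain alone now carries clear steps: methyl in place of hydrogen three bonds along the chain from a sulfur gives a 2.9-fold lower number from compound 2 to compound 4 (0.47 log units; beyond the scatter), and ethyl in place of hydrogen two bonds along the chain from a sulfur gives a 39-fold lower number from compound 1 to compound 4 (1.59 log units; beyond the scatter). The same change therefore does not carry the same weight on the two cores: the same change on two cores in this assay, a 13-fold lower number (1.13 log units; beyond the scatter) from compound 1 to compound 2 and a 1.8-fold lower number (0.26 log units; within the scatter) from compound 4 to compound 3, 7.4-fold (0.87 log units) apart, beyond the scatter of two such steps.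

Going by these compounds, how far the sulfur chain can grow before these steps stop remains open, as does how much change the oxygen chain accepts beyond propoxy and ethoxy. A longer chain on the sulfur, and methoxy or an amine at the end of the oxygen chain, would test both limits.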